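A few compounds are considered here, and "the series" means these few. Any claim that something is new, unique, unknown or untested is made for them only; others in the source may bear on it.

Compound 1, `C[Si](C)(C)CCOCn1c(CC(O)(CO)CO)cc(=O)[nH]c1=O`, gives > 100000 nM in a functional assay on HepG2 cells (Homo sapiens) for antiproliferative activity, read by MTT assay, with a stated time of 72 h (on this read-out lower numbers stand for stronger inhibition and higher numbers for weaker inhibition), which is a limit of the assay rather than a number. Compound 2, `Cc1c(CC(O)COCc2ccccc2)n(COCC[Si](C)(C)C)c(=O)[nH]c1=O`, gives > 100000 nM in this assay, again a limit. Compound 3, `C[Si](C)(C)CCOCn1c(CC(O)CO)cc(=O)[nH]c1=O`, gives > 100000 nM in this assay, also a limit.

Compound 3 therefore stands where every measured value in this set stands: at the limit, with no number to rank it against the others. Within the data shown here, the only step between two measured compounds that differ in one place, a step that the two limits leave unreadable from compound 1 to compound 3, is likewise unreadable, as both ends sit at the limit; this is summarised by the limit of > 100000 nM in this assay, at which 3 of the 3 values shown sit.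

Compound 4, `Cc1c(CC(O)CO)n(COCC[Si](C)(C)C)c(=O)[nH]c1=O`, has not yet been measured. It differs from compound 3 by methyl in place of hydrogen on an aromatic carbon. Among the measured compounds shown here, compound 2 already carries this same methyl on its core and reaches only the limit in this assay, so the one measured compound that shares the change gives no sign of activity. For the measured compounds named here, no measured step allows a readable prediction in either direction.

The estimate for compound 4 in this assay is 150000 nM, expected to fall between 50000 nM and 1000000 nM. The step that the limit leaves unreadable from compound 3 to compound 4 is expected to be none beyond the scatter, with another limit the most likely outcome.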

Compound 4, half-maximal inhibitory concentration: > 100000 nM
Compound 4 was reported as a limit; the forecaster's own chance of this, stated with the estimate: 85%; the middle value lies beyond the limit too.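

Compound 4 also gives only a limit, so the steps to it from compound 3 and compound 2 cannot be read, and the set as a whole offers no number to compare: the limit of > 100000 nM in this assay, at which 4 of the 4 values shown sit.

The compounds shown leave open whether any change to this shared core can bring a measurable value in this assay.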